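The source may hold more compounds than are shown below. What is called first, only, known or untested is meant among the compounds shown, and "the series" means these compounds.

Measured compounds in a physicochemical assay for solubility, read by HPLC, using the shake flask method, with a stated time of 2 h, at pH 2; a lower number here means a less soluble compound, a higher number a more soluble compound:
- compound 1 `Nc1ncc(-c2ccc(C(=O)N3CCC(N)C3)cc2)nc1-c1ccc(C(F)(F)F)cc1` gives 165000 nM
- compound 2 `Nc1ncc(-c2ccc(C(=O)N3CCC(O)CC3)cc2)nc1-c1ccc(C(F)(F)F)cc1` gives 119000 nM

Among the compounds with values here, compound 2 holds the lower of the two numbers in this assay so far; its nearest neighbour is compound 1, and the step of a 1.4-fold lower number from compound 1 to compound 2 (0.14 log units; within the scatter) lies within the scatter, so the two cannot be separated on these data.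

Compound 3 `Nc1ncc(-c2ccc(C(=O)N3CC[C@H](O)C3)cc2)nc1-c1ccc(C(F)(F)F)cc1` is the next member. It differs from compound 2 as follows: 3-hydroxypyrrolidin-1-yl in place of 4-hydroxypiperidin-1-yl on a carbonyl carbon

Within the data shown here, only one measured step bears on this change, the one from compound 1 to compound 2, a 1.4-fold lower number from compound 1 to compound 2 (0.14 log units; within the scatter), which exchanged one small saturated ring amide for another with no movement beyond the scatter. The change to compound 3 is of the same kind, a ring amide swap on the carbonyl carbon, so no step beyond the scatter is expected in this assay: the expected step is a 1.2-fold higher number from compound 2 to compound 3 (0.07 log units; within the scatter). Compound 3 is therefore estimated at 140000 nM, with a range from 70000 nM to 280000 nM.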

Compound 3, solubility: 93000 nM
The estimate for compound 3 lay 1.5-fold (0.18 log units) above the measured number; low and high end bracket the measured number.
By their numbers in this assay, from the lowest: compounds 3, 2 and 1 (each within the scatter of the next).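

In this assay the step of a 1.3-fold lower number from compound 2 to compound 3 (0.11 log units; within the scatter) leaves 3-hydroxypyrrolidin-1-yl and 4-hydroxypiperidin-1-yl on the carbonyl carbon unseparated, so the five-membered and six-membered rings read alike here. The same ring now also carries two different substituents, 3-hydroxypyrrolidin-1-yl against 3-aminopyrrolidin-1-yl, and the step of a 1.8-fold lower number from compound 1 to compound 3 (0.25 log units; within the scatter) puts that exchange within the scatter as well, so no difference among the three amides can be claimed at this position. No measurement available here accounts for these readings.

On these data alone, it remains open whether the opposite stereocentre in the 3-hydroxypyrrolidin-1-yl group would read the same. Also open, as far as these compounds go, is whether a carboxylic acid or a longer chain ending in a dimethylamino group on the carbonyl carbon would give a step beyond the scatter.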